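Replacing a Nitrile by an Amide on the Shared Core

The compounds below may be only part of what the source reports. "The series", "measured", "known", "first", "only" and "open" are said of these compounds alone.

Measured so far:
Compound 1, `CN(C)/N=N/c1ccc([N+](=O)[O-])cc1C(N)=O`, in a functional assay on L1210 cells (Mus musculus) for antiproliferative activity (on this read-out higher numbers stand for higher potency (the scale is a negative logarithm) and lower numbers for lower potency), gives 3.26.
Compound 2, `CN(C)/N=N/c1ccc(C#N)cc1C(N)=O`, in this assay gives 3.46.

Among these two numbers compound 2 stands highest, but only by a number 0.20 log units higher from compound 1 to compound 2 (within the scatter), so the two compounds cannot be told apart on this read-out. Compound 3, `CN(C)/N=N/c1ccc(C(N)=O)cc1C(N)=O`, has not yet been measured. It differs from compound 2 in one place: carbamoyl in place of cyano on an aromatic carbon. Among the compounds with values here, the only measured step, swapping nitro for cyano, left the number essentially unchanged, and no step in this set shows what a carbamoyl group does in that place. The expectation is therefore a step in this assay of a number 0.11 log units lower from compound 2 to compound 3 (within the scatter), which is no change beyond the scatter. Compound 3 is estimated at 3.35, with a range from 2.85 to 3.85.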

Compound 3, logarithm of the reciprocal of the active concentration, log(1/C): 3.27
For compound 3 the middle estimate is 0.08 log units above the measured one; the measured number falls inside the stated range.
By their numbers in this assay, from the lowest: compounds 1, 3 and 2 (each within the scatter of the next).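

In this assay, carbamoyl in place of cyano gives a number 0.19 log units lower from compound 2 to compound 3 (within the scatter), and carbamoyl in place of nitro gives a number 0.01 log units higher from compound 1 to compound 3 (within the scatter). Three different groups on this aromatic carbon, including a carbamoyl that carries a hydrogen-bond donor where cyano has none, therefore cannot be told apart on this read-out, so the swap to carbamoyl adds a second kind of step that stays inside the scatter. Nothing available here accounts for this flat result.

Going by these compounds, whether an amine or a carboxylic acid on the same aromatic carbon would also stay within the scatter of these three compounds, or would move the number beyond it, remains open. Also open, on these data alone, is what the carbamoyl group that stays in place on the shared core contributes, as it is present in all three compounds.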